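The source may hold more compounds than are shown below. What is called first, only, known or untested is meant among the compounds shown, and "the series" means these compounds.

Measured in a functional assay on KB-VIN10 cells (Homo sapiens) for inhibition, with a stated time of 72 h; on this read-out lower numbers stand for stronger inhibition and higher numbers for weaker inhibition:
- compound 1 `COc1ccc(S(=O)(=O)N2CCc3cccc(-c4ccc(F)nc4)c32)cc1`: 151 nM
- compound 2 `COc1ccc(S(=O)(=O)N2CCc3cccc(-c4cccc(F)c4)c32)cc1`: 92.4 nM

Of these two numbers, compound 2 at 92.4 nM cannot be separated from compound 1. Next is compound 3 `COc1ccc(S(=O)(=O)N2CCc3cccc(-c4cccs4)c32)cc1`, with thiophen-2-yl in place of 3-fluorophenyl on an aromatic carbon. Going by the values given here, the one measured swap at this place, a 1.6-fold lower number from compound 1 to compound 2 (0.21 log units; within the scatter), offers the only guide, and no thiophen-2-yl analogue has been measured. No step beyond the scatter is therefore expected in this assay. The estimated change is a 1.1-fold higher number from compound 2 to compound 3 (0.03 log units; within the scatter). For compound 3 the expected value is 100 nM, with an estimated range of 35 nM to 280 nM.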

Compound 3, half-maximal inhibitory concentration: 251 nM
Compound 3: the middle estimate sits 2.5-fold (0.40 log units) below what was measured; measured number inside the range.
By their numbers in this assay, from the lowest: compounds 2, 1 and 3 (each within the scatter of the next, the first and the last beyond it).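

At this position on the shared core, in this assay, a ring change now gives a step beyond the scatter: thiophen-2-yl in place of 3-fluorophenyl (a 2.7-fold higher number from compound 2 to compound 3 (0.43 log units; beyond the scatter)). Thiophen-2-yl in place of 6-fluoropyridin-3-yl stays within the scatter (a 1.7-fold higher number from compound 1 to compound 3 (0.22 log units; within the scatter)), so the effect of thiophen-2-yl here depends on the group it is compared with. Nothing available bears on the cause of this step.

Open, on these data alone, is how a non-aromatic group at this position, such as a piperidine or a carboxylic acid, would compare with these three aromatic rings. Also open, as far as these compounds go, is whether thiophen-3-yl would behave like thiophen-2-yl.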